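The source may report more compounds than this note shows. Statements on the series, on what has been measured and on what is new or still open speak of the compounds shown alone.

Compound 1 `Nc1nc(NCCNc2ncc(-c3ncc[nH]3)c(-c3ccc(Cl)cc3)n2)ccc1[N+](=O)[O-]`: > 0.5 h (a limit)
Compound 2 `Nc1nc(NCCNc2ncc(-c3ncc[nH]3)c(-c3ccc(F)cc3Cl)n2)ccc1[N+](=O)[O-]`: > 0.5 h (a limit)
Compound 3 `Nc1nc(NCCNc2ncc(-c3ncc[nH]3)c(-c3ccc(F)cc3C(F)(F)F)n2)ccc1[N+](=O)[O-]`: > 0.5 h (a limit)

All three results come from an ADME assay on microsomes from liver (Rattus norvegicus) for metabolic stability (a lower number here means that the compound disappears faster, a higher number that the compound lasts longer), and none is an exact number. Compound 3 stands only at a limit, > 0.5 h. The whole series shares this position: the limit of > 0.5 h in this assay, at which 3 of the 3 values shown sit.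

Compound 4 `Cc1ccc(-c2nc(NCCNc3ccc([N+](=O)[O-])c(N)n3)ncc2-c2ncc[nH]2)c(Br)c1` carries 2-bromo-4-methylphenyl in place of 4-fluoro-2-(trifluoromethyl)phenyl (2-bromo-4-methylphenyl in place of 4-fluoro-2-(trifluoromethyl)phenyl on an aromatic carbon). Three measured steps change this same group: a step that the two limits leave unreadable from compound 1 to compound 2, a step that the two limits leave unreadable from compound 1 to compound 3 and a step that the two limits leave unreadable from compound 2 to compound 3. None gives a size, so no direction can be drawn from them, and compound 4 is expected to stay within the scatter. The expected step is a step that the limit leaves unreadable from compound 3 to compound 4. For compound 4 the estimated half-life is 0.6 h, with an expected range of 0.3 h to 1.5 h.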

Compound 4, half-life: > 0.5 h
Compound 4 was reported as a limit (the forecaster's own chance of this, stated with the estimate: 70%); the middle value does not contradict the limit.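

Compound 4 gives no readable step against compound 1, compound 2 or compound 3 in this assay, and all four share one position: the limit of > 0.5 h in this assay, at which 4 of the 4 values shown sit. The compounds shown leave open each exact half-life and whether changing this group alters it.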